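Methyl on the triazole-bound phenyl of compound 1

The source may hold more compounds than are shown below. What is called first, only, known or untested is meant among the compounds shown, and "the series" means these compounds.

Compound 1, with the structure `N#CC1=C(N)Oc2c(c3nc4ccccc4nc3c3ccccc23)C12C(=O)N(Cc1cnnn1-c1cccc(Cl)c1)c1ccccc12`, is one of three close analogues that vary only in the aryl group on the triazole nitrogen. In a functional assay on MCF7 cells (Homo sapiens) for antiproliferative activity, read by MTT assay, with a stated time of 48 h (a lower number here means a stronger inhibitor, a higher number a weaker inhibitor), compound 1 gives 43600 nM, the higher of the two numbers recorded in the set. Compound 2, `N#CC1=C(N)Oc2c(c3nc4ccccc4nc3c3ccccc23)C12C(=O)N(Cc1cnnn1-c1ccc(Br)cc1)c1ccccc12`, gives 36600 nM in this assay, and the step of a 1.2-fold lower number from compound 1 to compound 2 (0.08 log units; within the scatter) stays within the scatter. Compound 3, `Cc1ccc(-n2nncc2CN2C(=O)C3(C(C#N)=C(N)Oc4c3c3nc5ccccc5nc3c3ccccc43)c3ccccc32)cc1Cl`, does not return a number in this assay: its value, > 50000 nM, is a limit. One of the three values recorded thus sits at the limit of > 50000 nM in this assay, at which 1 of the 3 values shown sits.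

Compound 4, `Cc1ccc(Cl)cc1-n1nncc1CN1C(=O)C2(C(C#N)=C(N)Oc3c2c2nc4ccccc4nc2c2ccccc32)c2ccccc21`, is the next member to be measured. It differs from compound 1 by methyl in place of hydrogen on an aromatic carbon. Going by the values given here, the only measured step of the same kind, an at least 1.1-fold higher number from compound 1 to compound 3 (0.05 log units; that floor lies within the scatter), placed the methyl at a different position of the phenyl ring and ended at the limit; the step of an at least 1.3-fold higher number from compound 2 to compound 3 (0.13 log units; that floor lies within the scatter) is similar. Both floors lie within the scatter, so the evidence supports no change beyond the scatter, while leaving open that a methyl may carry compound 4 to the limit as well.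

For compound 4 in this assay the expected value is 48000 nM, within 24000 nM to 96000 nM, meaning an estimated step of a 1.1-fold higher number from compound 1 to compound 4 (0.04 log units; within the scatter).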

Compound 4, half-maximal inhibitory concentration: > 50000 nM
Compound 4: no number, only a limit (the forecaster's own chance of this, stated with the estimate: 45%); middle value at least 1.0-fold (0.01 log units) from the limit.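

The position ortho to a large group and para to the chloro group is a second place on this phenyl ring where methyl in place of hydrogen ends at a limit rather than a number in this assay, after the placement in compound 3. The readable steps are an at least 1.1-fold higher number from compound 1 to compound 4 (0.05 log units; that floor lies within the scatter) and an at least 1.3-fold higher number from compound 2 to compound 4 (0.13 log units; that floor lies within the scatter), so neither floor shows a change beyond the scatter, and the steps involving two limits, such as that between compound 3 and compound 4, cannot be read. The two methyl placements therefore cannot be ranked, and the upper end of the series now holds more compounds: the limit of > 50000 nM in this assay, at which 2 of the 4 values shown sit.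

On these data alone, the true size of the methyl step remains open, as the limit for compound 4 gives only a floor, and a real loss and no change at all both remain compatible with the floors printed. Also open, as far as these compounds go, is whether a different group at this same position, such as an amine, a hydroxyl or a carboxylic acid, would return a number in this assay and separate from compound 1 by more than the scatter.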